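This account rests on a few compounds, and the source may have more. Where it says the series, first, only, none or still open, it means among the compounds named here.

Measured so far:
- Compound 1 `CC(C)(C)OC(=O)NCCCCCCCCCCCC(=O)O[C@H]1[C@H](O)[C@@H](CO)O[C@H]1n1cc(/C=C/Br)c(=O)[nH]c1=O` gives "not determined" (no result reported) in an assay on isolated protein for inhibition of thymidine kinase, cytosolic (Homo sapiens); on this read-out lower numbers stand for stronger inhibition and higher numbers for weaker inhibition.
- Compound 2 `CCCCCCCC(=O)O[C@H]1[C@H](O)[C@@H](CO)O[C@H]1n1cnc2c(=O)[nH]c(N)nc21` gives > 500000 nM in this assay.

The value for compound 2 is a limit of this assay, not a number: the measurement stopped there without finding inhibition. This is where compound 2 stands on the numbers shown, at the limit of > 500000 nM in this assay, at which 1 of the 2 values shown sits, while compound 1 has no result at all.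

Compound 3 `CCCCCCCC(=O)Nc1nc2c(ncn2[C@@H]2O[C@H](CO)[C@@H](O)[C@@H]2OC(=O)CCCCCCC)c(=O)[nH]1` differs from compound 2 in one place: heptylcarbonyl in place of hydrogen on a nitrogen on an aromatic ring. The change puts a heptylcarbonyl on a nitrogen on an aromatic ring whose other neighbour is an aromatic carbon, turning an amino group into a (heptylcarbonyl)amino group. Among the measured compounds shown here, since compound 2 sits at the limit of this assay, no step between measured compounds can guide the expectation. The expected step from compound 2 to compound 3 is a number no higher from compound 2 to compound 3 (the limit leaves the size open), that is, none beyond the scatter. Compound 3 is therefore estimated at 500000 nM, with a range from 100000 nM to 2000000 nM.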

Compound 3, half-maximal inhibitory concentration: > 500000 nM
Compound 3 was reported as a limit; the forecaster's own chance of this, stated with the estimate: 85%; the middle value sits exactly at the limit.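

No step can be read from compound 2 to compound 3, because both results are limits and not numbers: the limit of > 500000 nM in this assay, at which 2 of the 3 values shown sit. The compounds shown leave open how strongly either compound acts in this assay, and whether the heptylcarbonyl in place of hydrogen changes anything.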